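Adding a Second Chloro Group: What Compound 4 Might Show

The source may hold more compounds than are shown below. What is called first, only, known or untested is meant among the compounds shown, and "the series" means these compounds.

Measured so far in a functional assay on the whole organism (Pleural cavity) for inhibition, with Rattus norvegicus as the target, at a dose of 25 mg/kg; a lower number here means less inhibition, a higher number more inhibition at the dose given (going by the name of the read-out):
compound 1, `CC1(C)C(=O)N(c2ccc(Cl)cc2Cl)c2ncccc21`, gives 16%;
compound 2, `CC1(C)C(=O)N(c2ccccc2Cl)c2ncccc21`, gives 14%;
compound 3, `CC1(C)C(=O)N(c2cccc(Cl)c2)c2ncccc21`, gives 51%.

Compound 3 stands highest of the three, and its steps to compound 1 and to compound 2 are both beyond the scatter. Compound 3 and compound 2 are built from the same atoms joined differently; the difference between the two cores is not broken down here. Compound 1 differs from compound 2 by chloro in place of hydrogen on an aromatic carbon, and in this assay that change gave a number 2 percentage points higher from compound 2 to compound 1 (within the scatter).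

Compound 4, `CC1(C)C(=O)N(c2cc(Cl)cc(Cl)c2)c2ncccc21`, has not yet been measured. It differs from compound 3 by chloro in place of hydrogen on an aromatic carbon. For the measured compounds named here, this is the same kind of change as the one from compound 2 to compound 1, but not the same: in compound 1 the entering chloro is para to a large group, in compound 4 it is meta to a large group. Because the earlier step was a number 2 percentage points higher from compound 2 to compound 1 (within the scatter), the expected step here is a number 3 percentage points lower from compound 3 to compound 4 (within the scatter), with extra uncertainty from the changed place. Compound 4 is estimated at 48%, most likely between 30% and 66%.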

Compound 4, a percentage reported as inhibition, in the whole organism at one dose (the size of the read-out at that dose, not a potency): 49%
For compound 4 the middle estimate is 1 percentage points below the measured one; low and high end bracket the measured number.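

In this assay, chloro in place of hydrogen on an aromatic carbon gave a number 2 percentage points lower from compound 3 to compound 4 (within the scatter). Set beside the earlier case, the same change reads alike on the two cores, even though compound 2 gives 14% and compound 3 gives 51% before the chloro enters: the same change on two cores in this assay, a number 2 percentage points higher (within the scatter) from compound 2 to compound 1 and a number 2 percentage points lower (within the scatter) from compound 3 to compound 4, 4 percentage points apart, within the scatter of two such steps This shows that, in these two cases, the added chloro did not move the read-out beyond the usual scatter, but two cases do not make a rule, the chloro enters at a different place in each, and the result does not explain why the starting compounds stand so far apart.

The compounds shown leave open whether another group in place of this chloro, such as a methoxy group, an amine or a carboxylic acid, would read the same way on both cores. They also leave open whether the same picture would hold at other doses, since a single dose gives the size of the read-out and not a potency.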